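The compounds below may be only part of what the source reports. "The series", "measured", "known", "first", "only" and "open" are said of these compounds alone.

Measured compounds:
compound 1 `FC(F)(F)c1ccc(CSc2nc(Nc3ccccc3C(F)(F)F)c3ccccc3n2)cc1` — > 50000 nM
compound 2 `Cc1ccc(Nc2nc(SCc3ccc(C(F)(F)F)cc3)nc3ccccc23)cc1` — > 50000 nM
compound 3 `COc1ccc(Nc2nc(SCc3ccc(C(F)(F)F)cc3)nc3ccccc23)cc1OC` — 18900 nM

In a functional assay on MDA-MB-231 cells (Homo sapiens) for cytotoxicity, read by MTT assay, with a stated time of 72 h (on this read-out lower numbers stand for stronger inhibition and higher numbers for weaker inhibition), compound 1 gives > 50000 nM, which is a limit of the assay rather than a number. Compound 2 likewise stays at a limit, > 50000 nM. Compound 3 gives 18900 nM. Compound 1 thus stands at the weak end of the shown values, sharing the limit of > 50000 nM in this assay, at which 2 of the 3 values shown sit, with compound 2, while compound 3 is at least modestly lower, as an at least 2.6-fold lower number from compound 1 to compound 3 (0.42 log units; beyond the scatter) shows; a step that the two limits leave unreadable from compound 1 to compound 2 is not readable. Compound 4 `Fc1ccc(Nc2nc(SCc3ccc(C(F)(F)F)cc3)nc3ccccc23)cc1Cl` differs from compound 1 by 3-chloro-4-fluorophenyl in place of 2-(trifluoromethyl)phenyl on a nitrogen on an aromatic ring. Among the measured compounds shown here, no measured step concerns a 3-chloro-4-fluorophenyl, so compound 4 is expected to remain weak, with an at least 1.2-fold lower number from compound 1 to compound 4 (0.09 log units; that floor lies within the scatter) most likely small. Compound 4 is estimated at 40000 nM, within 12000 nM to 120000 nM.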

Compound 4, half-maximal inhibitory concentration: 14500 nM
For compound 4 the middle estimate is 2.8-fold (0.44 log units) above the measured one; low and high end bracket the measured number.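

Among the compounds shown here, the 3-chloro-4-fluorophenyl shows that 3,4-dimethoxyphenyl is not the only group on this nitrogen that gives a readable value: the change brings an at least 3.4-fold lower number from compound 1 to compound 4 (0.53 log units; beyond the scatter), and an at least 3.4-fold lower number from compound 2 to compound 4 (0.53 log units; beyond the scatter). Against the 3,4-dimethoxyphenyl there is a 1.3-fold lower number from compound 3 to compound 4 (0.12 log units; within the scatter), so these two groups cannot be told apart. Compound 1 and compound 2 remain at a limit: the limit of > 50000 nM in this assay, at which 2 of the 4 values shown sit.

On these data alone, whether the chlorine or the fluorine alone would give the same step stays open. So does what an unsubstituted phenyl, or a phenyl bearing an amine or a carboxylic acid, would do at this place.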